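The source may report more compounds than this note shows. Statements on the series, on what has been measured and on what is new or still open speak of the compounds shown alone.

Measured so far in a functional assay on K562 cells (Homo sapiens) for cytotoxicity, read by MTT assay, with a stated time of 72 h; a higher number here means a weaker inhibitor of growth, a lower number a stronger inhibitor of growth:
compound 1 `C[Se]/C(=N\C(=O)c1cccs1)NC(=O)c1cccs1` — a limit of the assay only, > 100000 nM.
compound 2 `O=C(/N=C(/NC(=O)c1cc(-c2ccccc2)nc2ccccc12)[Se]Cc1ccccc1)c1cc(-c2ccccc2)nc2ccccc12` — 47400 nM.
compound 3 `O=C(/N=C(/NC(=O)c1cccs1)[Se]Cc1ccccc1)c1cccs1` — 58500 nM.

Compound 3 holds the higher of the two numbers in this assay, but the value of compound 2 lies within the usual scatter of it, so the two cannot be told apart. The value of compound 1 is a limit, recorded as the limit of > 100000 nM in this assay, at which 1 of the 3 values shown sits.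

Compound 4 `CS/C(=N\C(=O)c1cccs1)NC(=O)c1cccs1` differs from compound 3 by a group of 2 heavy atoms (1 carbon, 1 sulfur; no ring) in place of a group of 8 heavy atoms (7 carbon, 1 selenium; one six-membered aromatic ring of carbon only), on a carbon with a double bond to nitrogen. For the measured compounds named here, only one measured step bears on this change: an at least 1.7-fold lower number from compound 1 to compound 3 (0.23 log units; that floor lies within the scatter). That step added a phenyl at the same position and gave, at most, a lowering that did not clear the scatter, since the starting point was a limit. Going from compound 3 to compound 4 removes that phenyl again, and also exchanges selenium for sulfur, for which no measured pair exists in the series. Going by the values given here, on the evidence of the single step, the number is expected to move back upward, by a 1.7-fold higher number from compound 3 to compound 4 (0.23 log units; within the scatter), and may well reach the limit again. The estimate for compound 4 in this assay is therefore 100000 nM, with a range from 40000 nM to 250000 nM, and a substantial chance that only a limit is reported.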

Compound 4, concentration for total growth inhibition: > 100000 nM
Compound 4 ended at the assay's limit; the forecaster's own chance of this, stated with the estimate: 55%; the middle value lies on the limit itself.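

In this assay, methylsulfanyl entering for the group of 8 heavy atoms, on a carbon with a double bond to nitrogen, gives an at least 1.7-fold higher number from compound 3 to compound 4 (0.23 log units; that floor lies within the scatter); this second step at the position again yields only a floor that does not clear the scatter. Compound 4 joins compound 1 at a limit, and both groups of 2 heavy atoms, the one with selenium and the one with sulfur, leave the read-out at the same limit: the limit of > 100000 nM in this assay, at which 2 of the 4 values shown sit. The step from compound 1 to compound 4, the only exchange of selenium for sulfur among these compounds, cannot be read: both ends are limits, and that exchange stays without a size.

Compound 3 and compound 4 differ in both the phenyl and the selenium atom at once, and a sulfur analogue of compound 3 that keeps the phenyl would be needed to separate the two. Also open, going by these compounds, is how a longer chain, an amine or a carboxylic acid in place of the phenyl on the saturated chain carbon would read in this assay.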